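A few compounds are considered here, and "the series" means these few. Any claim that something is new, unique, unknown or untested is made for them only; others in the source may bear on it.

Measured compounds:
compound 1 `COc1ccc2ncc(S(=O)(=O)c3cccc(Cl)c3)c(N3CCC(C)CC3)c2c1`: -3%
compound 2 `CC1CCN(c2c(S(=O)(=O)c3ccc(Cl)cc3)cnc3ccc(F)cc23)CC1`: 80%

In an assay on isolated protein for displacement of a labelled ligand from metabotropic glutamate receptor 5 (Homo sapiens), with a stated time of 60 min, tested at 1 uM (a higher number here means more inhibition at the concentration tested (going by the name of the read-out), a lower number less inhibition), compound 2 gives 80%, the highest of the two numbers, and compound 1 gives -3%, a gap beyond the scatter. Compound 3 `CC1CCN(c2c(S(=O)(=O)c3cccc(Cl)c3)cnc3ccc(F)cc23)CC1` is not yet measured. From compound 2 to compound 3 the change is 3-chlorophenyl in place of 4-chlorophenyl on a sulfonyl sulfur. Among the compounds with values here, no measured pair shares exactly this change. Compound 1 also carries a 3-chlorophenyl, yet it differs from compound 3 elsewhere too, so a drop is expected but its size is uncertain. The step of a number 45 percentage points lower from compound 2 to compound 3 (beyond the scatter) is the expected loss. Compound 3 is estimated at 35%, between 0% and 75%.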

Compound 3, a percentage reported as inhibition, at one concentration (the size of the read-out at that concentration, not a potency): 92%
The estimate for compound 3 lay 57 percentage points below the measured number; measured number above the stated range.
By their numbers in this assay, from the lowest: compound 1; then compound 2; then compound 3.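

In this assay, 3-chlorophenyl in place of 4-chlorophenyl on a sulfonyl sulfur gives a number 12 percentage points higher from compound 2 to compound 3 (beyond the scatter), so the 3-chlorophenyl is compatible with strong inhibition when the rest of the structure is that of compound 3. Compound 1 carries the same 3-chlorophenyl, yet its inhibition is near absent. Fluoro in place of methoxy on an aromatic carbon gives a number 95 percentage points higher from compound 1 to compound 3 (beyond the scatter), the largest step shown. On these data alone, whether methoxy is equally poor alongside a 4-chlorophenyl stays open, as does how a plain phenyl or a 3-methoxyphenyl on the sulfonyl sulfur would behave. Nothing measured here explains either step.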